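Chloro to isopropyl: an expected step

The source may report more compounds than this note shows. Statements on the series, on what has been measured and on what is new or still open speak of the compounds shown alone.

compound 1 `O=C(/C=C/c1ccc(/C=C/C(=O)c2cccc(Cl)c2)o1)NO`: 9600 nM
compound 2 `O=C(/C=C/c1ccc(/C=C/C(=O)c2ccccc2)o1)NO`: 13300 nM
compound 3 `O=C(/C=C/c1ccc(/C=C/C(=O)c2ccc(Cl)cc2)o1)NO`: 1350 nM

In a functional assay on PC-3 cells (Homo sapiens) for antiproliferative activity, read by MTT assay, with a stated time of 48 h (a lower number here means a stronger inhibitor, a higher number a weaker inhibitor), compound 3 gives the lowest of the three numbers, 1350 nM. Compound 4 `CC(C)c1ccc(C(=O)/C=C/c2ccc(/C=C/C(=O)NO)o2)cc1` carries isopropyl in place of chloro on an aromatic carbon. For the measured compounds named here, two measured steps bear on this change. One is a 9.9-fold lower number from compound 2 to compound 3 (0.99 log units; beyond the scatter), and the other is a 7.1-fold lower number from compound 1 to compound 3 (0.85 log units; beyond the scatter). Going by the values given here, no measured compound carries isopropyl, so the size of the new step is uncertain. Some of the gain seen in a 9.9-fold lower number from compound 2 to compound 3 (0.99 log units; beyond the scatter) is expected to be lost. The expected step is a 1.9-fold higher number from compound 3 to compound 4 (0.27 log units; within the scatter), a modest rise. Compound 4 is estimated at 2500 nM, with an expected range from 800 nM to 8000 nM.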

Compound 4, half-maximal inhibitory concentration: 2270 nM
Compound 4: middle estimate off by 1.1-fold (0.04 log units), on the high side, within the range that was stated.
By their numbers in this assay, from the lowest: compounds 3 and 4 (each within the scatter of the next); then compounds 1 and 2 (each within the scatter of the next).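

In this assay the lower number at this place, on an aromatic carbon para to a large group, does not belong to chloro alone. Isopropyl, with 3 carbon atoms in place of 1 chlorine, gives a 1.7-fold higher number from compound 3 to compound 4 (0.23 log units; within the scatter) and, set against hydrogen, a 5.9-fold lower number from compound 2 to compound 4 (0.77 log units; beyond the scatter) at the same place. Nothing measured here explains why these two groups give such similar numbers.

The compounds shown leave open whether an amine, a methoxy group or a longer chain would keep this lower number. They also leave open what isopropyl would do at the place where compound 1 carries chloro.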